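A few compounds are considered here, and "the series" means these few. Any claim that something is new, unique, unknown or untested is made for them only; others in the source may bear on it.

Among the compounds with values here, compound 3 (`C/C(=N\Nc1nc(-c2ccccn2)cs1)c1ccc(Cl)c(Cl)c1`) gives 10200 nM in an ADME assay on H9c2 cells (Rattus norvegicus) for cytotoxicity, read by resazurin assay, with a stated time of 72 h (a higher number here means that more compound is tolerated, a lower number that less compound is tolerated), the only number so far. Compound 1 (`C/C(=N\Nc1nc(C)c(C)s1)c1ccc(Cl)c(Cl)c1`) gives > 50000 nM, which is a limit. Compound 2 (`C/C(=N\Nc1nc(-c2ccccc2)c(C)s1)c1ccc(Cl)c(Cl)c1`) gives > 50000 nM, also a limit. The rest of the data therefore sit at the limit of > 50000 nM in this assay, at which 2 of the 3 values shown sit.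

The next structure is compound 4 (`C/C(=N\Nc1nc(-c2ccc(Cl)cc2)cs1)c1ccc(Cl)c(Cl)c1`), with 4-chlorophenyl in place of pyridin-2-yl on an aromatic carbon. Within the data shown here, the one step between measured compounds, a step that the two limits leave unreadable from compound 1 to compound 2, has no readable size, and no measured pair isolates this swap. Compound 2 carries phenyl, an aromatic ring of carbon only, and its reading of > 50000 nM is a limit, which leans the expectation upward.

A modest upward move in this assay is expected, estimated as a 2.5-fold higher number from compound 3 to compound 4 (0.39 log units; beyond the scatter). The support is thin, so the expected range is wide. For compound 4 the estimated value is 25000 nM, with an expected range of 8000 nM to 50000 nM.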

Compound 4, half-maximal cytotoxic concentration: > 50000 nM
Compound 4 was reported as a limit; the forecaster's own chance of this, stated with the estimate: 30%; middle value at least 2.0-fold (0.30 log units) from the limit.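

Within the data shown here, at this aromatic carbon, next to the ring nitrogen, 4-chlorophenyl in place of pyridin-2-yl gives the first readable step in this assay: an at least 4.9-fold higher number from compound 3 to compound 4 (0.69 log units; beyond the scatter). The change therefore moves the read-out beyond the scatter, and the direction is toward more compound being tolerated. In the same assay, compound 4 gives > 50000 nM, which is a limit, so the step has a lower bound but no full size: the limit of > 50000 nM in this assay, at which 3 of the 4 values shown sit.

The swap changes both the ring nitrogen of pyridin-2-yl and the chlorine of 4-chlorophenyl at once, and the compounds shown do not separate the two. Also open, going by these compounds, is how a pyridin-3-yl ring, an amine or a carboxylic acid at this carbon would read in this assay.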